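Notes on the step from compound 3 to compound 4

The source may report more compounds than this note shows. Statements on the series, on what has been measured and on what is new or still open speak of the compounds shown alone.

Measured in an ADME assay on MT4 cells (Homo sapiens) for cytotoxicity, read by MTT assay; on this read-out lower numbers stand for higher toxicity in this test and higher numbers for lower toxicity in this test:
- compound 1 `Cc1ccccc1C(=O)N(C(=S)OCCN1C(=O)c2ccccc2C1=O)c1ccc(Cl)cc1` 21000 nM
- compound 2 `Cc1ccc(N(C(=O)c2ccccc2[N+](=O)[O-])C(=S)OCCN2C(=O)c3ccccc3C2=O)cc1` 100000 nM
- compound 3 `O=C1c2ccccc2C(=O)N1CCOC(=S)N(C(=O)c1cccc(F)c1F)c1ccc(Cl)cc1` 58000 nM

In this assay compound 3 lies within the usual scatter of compound 2 and clearly above compound 1. Compound 4 `O=C1c2ccccc2C(=O)N1CCOC(=S)N(C(=O)c1c(Cl)cccc1Cl)c1ccc(Cl)cc1` differs from compound 3 as follows: 2,6-dichlorophenyl in place of 2,3-difluorophenyl on a carbonyl carbon. That is, 2,6-dichlorophenyl in place of 2,3-difluorophenyl on a carbonyl carbon. For the measured compounds named here, the one measured step at this place is a 2.8-fold higher number from compound 1 to compound 3 (0.44 log units; beyond the scatter). A step of that modest size or smaller is therefore expected in this assay, tilted towards a lower number and possibly no larger than the scatter. The expected step is a 1.5-fold lower number from compound 3 to compound 4 (0.16 log units; within the scatter). For compound 4 the estimated value is 40000 nM, with an expected range of 15000 nM to 100000 nM.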

Compound 4, half-maximal cytotoxic concentration: 20000 nM
Compound 4: the middle estimate sits 2.0-fold (0.30 log units) above what was measured; the measured number falls inside the stated range.
By their numbers in this assay, from the lowest: compounds 4 and 1 (each within the scatter of the next); then compounds 3 and 2 (each within the scatter of the next).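

In this assay, this carbonyl position now shows a drop as well as a rise: a 2.9-fold lower number from compound 3 to compound 4 (0.46 log units; beyond the scatter), which reverses the size of the earlier step from the 2-methylphenyl compound. Exchanging 2-methylphenyl for 2,6-dichlorophenyl leaves the number within the scatter, a 1.1-fold lower number from compound 1 to compound 4 (0.02 log units; within the scatter), so the 2,3-difluorophenyl compound remains apart from these two. Nothing available bears on why these groups differ. Open, on these data alone, is how a phenyl carrying an amine or a carboxylic acid would read at this place, and whether a single chlorine would read like 2,6-dichlorophenyl.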